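A few compounds are considered here, and "the series" means these few. Any claim that something is new, unique, unknown or untested is made for them only; others in the source may bear on it.

Measured so far:
Compound 1 `NC(=O)c1cc2ccc(OCC(F)(F)F)cc2n1-c1cccc(CCC(=O)O)c1` in an assay for inhibition of Group 10 secretory phospholipase A2 (Homo sapiens), with stated times of 20 min and 60 min (a lower number here means a stronger inhibitor, a higher number a weaker inhibitor), gives 93 nM.
Compound 2 `NC(=O)c1cc2ccc(OC(F)F)cc2n1-c1cccc(CCC(=O)O)c1` gives 68 nM.
Compound 3 `NC(=O)c1cc2ccc(C3CC3)cc2n1-c1cccc(CCC(=O)O)c1` gives 160 nM.

Compound 3 shows the highest number of the three; its gap to compound 1 lies within the scatter, whereas a 2.4-fold higher number from compound 2 to compound 3 (0.37 log units; beyond the scatter) lies beyond it. Compound 4 `NC(=O)c1cc2ccc(C(F)(F)F)cc2n1-c1cccc(CCC(=O)O)c1` differs from compound 3 by trifluoromethyl in place of cyclopropyl on an aromatic carbon. Going by the values given here, no measured step exchanges these two groups directly. The nearest comparisons are a 1.7-fold higher number from compound 1 to compound 3 (0.24 log units; within the scatter) and a 2.4-fold higher number from compound 2 to compound 3 (0.37 log units; beyond the scatter), in which the cyclopropyl gave the higher numbers against the two fluorinated ethers. Read in reverse, a fluorine-bearing group at that carbon leaned toward lower numbers, but compound 4 carries its fluorines without an ether oxygen, so only a small step is expected, a 1.5-fold lower number from compound 3 to compound 4 (0.16 log units; within the scatter). Compound 4 is therefore estimated at 110 nM, with a range from 50 nM to 250 nM.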

Compound 4, half-maximal inhibitory concentration: 43 nM
Beside the measured number, compound 4's estimate is 2.6-fold (0.41 log units) above it; the whole stated range lies above it.
By their numbers in this assay, from the lowest: compounds 4, 2, 1 and 3 (each within the scatter of the next, the first and the last beyond it).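

In this assay the change from cyclopropyl to trifluoromethyl on this aromatic carbon gives a 3.7-fold lower number from compound 3 to compound 4 (0.57 log units; beyond the scatter) and is the largest step among the four compounds. An ether oxygen is thus not required for a low number: replacing 2,2,2-trifluoroethoxy with trifluoromethyl gives a 2.2-fold lower number from compound 1 to compound 4 (0.34 log units; beyond the scatter) while replacing difluoromethoxy gives a 1.6-fold lower number from compound 2 to compound 4 (0.20 log units; within the scatter) and leaves those two compounds unseparated. Nothing available explains why these groups differ.

On these data alone, whether a nitrile, an amine or a longer fluorinated chain on this carbon would give a similarly low number remains open.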